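Ring expansion and hydroxy removal in the amidine series

A few compounds are considered here, and "the series" means these few. Any claim that something is new, unique, unknown or untested is made for them only; others in the source may bear on it.

Compound 2 `O=C(N[C@@H](CCC(=O)N1CCN(c2cccc(NC3=NCC(O)CN3)c2)CC1)C(=O)O)OCc1ccccc1` gives 3.5 nM in a functional assay (muscle tissue) for inhibition, with Homo sapiens as the target (a higher number here means a weaker inhibitor, a lower number a stronger inhibitor), the highest of the two numbers obtained so far. Its nearest neighbour is compound 1 `O=C(N[C@@H](CCC(=O)N1CCN(c2cccc(NC3=NCCCN3)c2)CC1)C(=O)O)OCc1ccccc1`, which in this assay gives 1.1 nM; the two are separated by a 3.2-fold higher number from compound 1 to compound 2 (0.50 log units; beyond the scatter), a hydroxy in place of hydrogen on a saturated ring carbon. Compound 3 `O=C(N[C@@H](CCC(=O)N1CCN(c2cccc(NC3=NCCCCN3)c2)CC1)C(=O)O)OCc1ccccc1` has not been measured. It differs from compound 2 by a group of 7 heavy atoms (5 carbon, 2 nitrogen; one seven-membered non-aromatic ring with 2 hetero atoms) in place of a group of 7 heavy atoms (4 carbon, 2 nitrogen, 1 oxygen; one six-membered non-aromatic ring with 2 hetero atoms), on a nitrogen on an aromatic ring. Two things happen in that change: the hydroxy leaves, and the ring gains one carbon. Going by the values given here, only one measured step bears on this, and only on the first part; it showed a 3.2-fold higher number from compound 1 to compound 2 (0.50 log units; beyond the scatter), so taking the hydroxy away would be expected to undo most of that rise. On these data alone, for the ring enlargement the series holds no measured comparison, so its contribution is unknown and widens the range. The step expected from compound 2 to compound 3 in this assay is a 2.3-fold lower number from compound 2 to compound 3 (0.37 log units; beyond the scatter). For compound 3 the estimate in this assay is 1.5 nM, with a range from 0.5 nM to 5 nM.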

Compound 3, half-maximal inhibitory concentration: 1.7 nM
Compound 3: the middle estimate sits 1.1-fold (0.05 log units) below what was measured, and the stated range covers the measured number.
By their numbers in this assay, from the lowest: compounds 1 and 3 (each within the scatter of the next); then compound 2.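

In this assay the exchange of the six-membered ring carrying the hydroxy for the seven-membered ring without it gives a 2.1-fold lower number from compound 2 to compound 3 (0.31 log units; beyond the scatter) and so adds a second comparison at this position, on a nitrogen on an aromatic ring. Ring size now has a measured comparison of its own, with the hydroxy absent from both compounds: a 1.5-fold higher number from compound 1 to compound 3 (0.19 log units; within the scatter) lies within the scatter, so the six-membered and seven-membered rings cannot be told apart here. Among the three compounds, only compound 2, the one with the hydroxy, stands apart, with its steps to both others printed as beyond the scatter.

On these data alone, whether a hydroxy on the seven-membered ring would carry the same penalty as on the six-membered ring remains open. Also open, as far as these compounds go, is how a five-membered ring, an eight-membered ring or an open-chain guanidine would read at this position. Nothing at hand explains the size of these steps.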